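Methyl Replaces Methoxy: From Compound 1 to Compound 4

The compounds below may be only part of what the source reports. "The series", "measured", "known", "first", "only" and "open" are said of these compounds alone.

Three compounds have been measured in a functional assay on HT-29 cells (Homo sapiens) for antiproliferative activity, read by sulforhodamine B assay, with a stated time of 72 h; a higher number here means a weaker inhibitor, a lower number a stronger inhibitor:

compound 1 `COc1ccccc1NC(=S)N/N=C/c1ccc2ccccc2n1`: > 100000 nM, a limit of the assay
compound 2 `NC(=S)N/N=C/c1cc2ccccc2s1`: 99200 nM
compound 3 `NC(=S)N/N=C/c1nc2ccccc2s1`: > 100000 nM, a limit of the assay

The value of compound 1 is a limit, not a number. Compound 3 likewise sits at a limit. Only compound 2 gives a number, and compound 1 stands at the weak end of the figures shown, where two of the three values rest at the limit (the limit of > 100000 nM in this assay, at which 2 of the 3 values shown sit). Compound 4 `Cc1ccccc1NC(=S)N/N=C/c1ccc2ccccc2n1` differs from compound 1 by methyl in place of methoxy on an aromatic carbon. Going by the values given here, no measured step is available to guide this change, so no step beyond the scatter is expected in this assay, in either direction; the estimated step of a number no higher from compound 1 to compound 4 (the limit leaves the size open) is expected to be essentially flat. Compound 4 is therefore expected to give 100000 nM, in an estimated range from 30000 nM to 300000 nM.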

Compound 4, half-maximal inhibitory concentration: 42300 nM
For compound 4 the middle estimate is 2.4-fold (0.37 log units) above the measured one, within the range that was stated.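

In this assay, going by these compounds alone, the change from 2-methoxyphenyl to 2-methylphenyl gives an at least 2.3-fold lower number from compound 1 to compound 4 (0.37 log units; beyond the scatter), so this place on the aromatic ring does respond to a change of group, which the earlier compounds could not show. Compound 4 gives a number, and compound 1 stays a limit of the assay, so the step has a floor but no fixed size: the limit of > 100000 nM in this assay, at which 2 of the 4 values shown sit.

The compounds shown leave open how an ethyl chain, a chlorine or an amine at this place would compare with methyl. They also leave open whether the same change would hold on another core.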